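The compounds below may be only part of what the source reports. "The series", "measured", "known", "first", "only" and "open" are said of these compounds alone.

Measured so far in an assay on isolated protein for inhibition of Rho-associated protein kinase 2 (Homo sapiens), read by scintillation counting, radiometric assay and 33P incorporation, with a stated time of 40 min, in the presence of a further agent that is not named here; a lower number here means a stronger inhibitor, a higher number a weaker inhibitor:
- compound 2 `O=C(COc1ccc2c(=O)ccoc2c1)Nc1cccc(NC(=O)c2ccc(Br)cc2)c1` gives 49 nM
- compound 1 `COc1cc(OCC(=O)Nc2cccc(NC(=O)c3ccc(N(C)C)cc3)c2)ccc1C=O` gives 306 nM

Of these two, compound 2 has the lower number, and compound 1 sits well above it, beyond the usual scatter. Compound 3 `Cc1cc(C(=O)Nc2cccc(NC(=O)COc3ccc4c(=O)ccoc4c3)c2)no1` is not yet measured in this assay. It differs from compound 2 in one place: 5-methyl-1,2-oxazol-3-yl in place of 4-bromophenyl on a carbonyl carbon. Among the compounds with values here, no measured pair shows a change of this kind, so the direction is uncertain; a modest step toward a higher number is expected, a 2.2-fold higher number from compound 2 to compound 3 (0.35 log units; beyond the scatter). Compound 3 is therefore estimated at 110 nM, with a range from 25 nM to 500 nM.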

Compound 3, half-maximal inhibitory concentration: 5 nM
For compound 3 the middle estimate is 22-fold (1.34 log units) above the measured one; the measured number lies below the stated range.
By their numbers in this assay, from the lowest: compound 3; then compound 2; then compound 1.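

In this assay, 5-methyl-1,2-oxazol-3-yl in place of 4-bromophenyl on a carbonyl carbon gives a 9.8-fold lower number from compound 2 to compound 3 (0.99 log units; beyond the scatter), so the group at this place strongly affects the number, and a large gain comes with a five-membered aromatic ring. The entering group counts 2 hydrogen-bond acceptors and the leaving group 0, but nothing shown ties that count to the gain, and no measurement here explains it.

The compounds shown leave open whether the methyl on the ring is needed, and whether a pyridine or unsubstituted phenyl would serve here. They also leave open whether the same swap would help on the core of compound 1.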